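A Pyridinyl Ether Replaces the Phenoxy Ring

The source may hold more compounds than are shown below. What is called first, only, known or untested is meant among the compounds shown, and "the series" means these compounds.

Compound 1 `O=C(Oc1ccc([N+](=O)[O-])cc1)N1CCN(S(=O)(=O)c2ccc(Oc3ccccc3)cc2)CC1` is the starting point. Within the data shown here, in an assay on isolated protein for inhibition of Fatty-acid amide hydrolase 1 (Homo sapiens), read by fluorescence (on this read-out lower numbers stand for stronger inhibition and higher numbers for weaker inhibition), compound 1 gives 322 nM, the second highest of the three numbers measured so far. Compound 2 `CCCCc1ccc(S(=O)(=O)N2CCN(C(=O)Oc3ccc([N+](=O)[O-])cc3)CC2)cc1` gives 179 nM in this assay, and compound 3 `O=C(Oc1ccc([N+](=O)[O-])cc1)N1CCN(S(=O)(=O)c2ccc(Oc3cccc(Cl)c3)cc2)CC1` gives 380 nM. The step of a 1.8-fold lower number from compound 1 to compound 2 (0.26 log units; within the scatter) and the step of a 1.2-fold higher number from compound 1 to compound 3 (0.07 log units; within the scatter) both stay within the scatter, while the step of a 2.1-fold higher number from compound 2 to compound 3 (0.33 log units; beyond the scatter) is modest.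

Compound 4 `O=C(Oc1ccc([N+](=O)[O-])cc1)N1CCN(S(=O)(=O)c2ccc(Oc3ncc(C(F)(F)F)cc3Cl)cc2)CC1` differs from compound 1 in one place: 3-chloro-5-(trifluoromethyl)pyridin-2-yl in place of phenyl on an oxygen on an aromatic ring. The step from compound 1 to compound 3 is the closest guide, since it too put chloro in place of hydrogen on an aromatic carbon of the same group and stayed within the scatter. The new ring in compound 4 also brings a nitrogen and a trifluoromethyl, a larger change than any measured here, so the outcome is less certain. Compound 4 is therefore expected to show a 1.1-fold higher number from compound 1 to compound 4 (0.04 log units; within the scatter). The estimate for compound 4 is 350 nM, with a range from 150 nM to 850 nM.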

Compound 4, half-maximal inhibitory concentration: 2950 nM
Estimate against measurement, compound 4: 8.4-fold (0.93 log units) below; the measured number lies above the stated range.
By their numbers in this assay, from the lowest: compounds 2, 1 and 3 (each within the scatter of the next, the first and the last beyond it); then compound 4.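

The oxygen-linked ring is not a freely interchangeable position: the step from phenyl to 3-chloro-5-(trifluoromethyl)pyridin-2-yl gives a 9.2-fold higher number from compound 1 to compound 4 (0.96 log units; beyond the scatter), whereas the earlier changes from compound 1 stayed within the scatter. A chloro on the ring does not account for this result by itself, since the comparison with the 3-chlorophenyl compound gives a 7.8-fold higher number from compound 3 to compound 4 (0.89 log units; beyond the scatter), and the comparison with the butyl compound gives the largest gap in the set, a 16-fold higher number from compound 2 to compound 4 (1.22 log units; beyond the scatter). No measurement here explains the loss of inhibition.

The ring nitrogen, the chloro and the trifluoromethyl all change together in compound 4, so their separate contributions remain unresolved. On these data alone, a plain pyridin-2-yl would help to separate them, and how an amine or a carboxylic acid on this ring would fare remains open.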